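(3-Methoxyphenyl)amino in Place of Piperidin-1-yl on Two Cores

The source may report more compounds than this note shows. Statements on the series, on what has been measured and on what is new or still open speak of the compounds shown alone.

Compound 1 `O=C1C(N2CCCCC2)=CC(=O)c2c1nc1n2[C@H]2OC[C@@H](O)[C@H]2OC1` gives a limit of the assay, > 8000 nM.
Compound 2 `COc1cccc(NC2=CC(=O)c3c(nc4n3[C@H]3OC[C@@H](O)[C@H]3OC4)C2=O)c1` gives 3830 nM.
Compound 3 `O=C1C=C(N2CCCCC2)C(=O)c2c1nc1n2[C@H]2OC[C@@H](O)[C@H]2OC1` gives a limit of the assay, > 8000 nM.

All three were tested in a functional assay on MCF7 cells (Homo sapiens) for inhibition, read by sulforhodamine B assay; on this read-out lower numbers stand for stronger inhibition and higher numbers for weaker inhibition. Compound 1 and compound 3 are built from the same atoms joined differently; the difference between the two cores is not broken down here. The result for compound 1 is a limit, not a number. The result for compound 3 is also a limit, not a number. Two of the three results thus sit at the limit of > 8000 nM in this assay, at which 2 of the 3 values shown sit.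

Compound 2 differs from compound 1 by (3-methoxyphenyl)amino in place of piperidin-1-yl on a double-bonded ring carbon, and this change gave an at least 2.0-fold lower number from compound 1 to compound 2 (0.31 log units; beyond the scatter). Compound 4 `COc1cccc(NC2=CC(=O)c3nc4n(c3C2=O)[C@H]2OC[C@@H](O)[C@H]2OC4)c1` carries the same change on the core of compound 3, namely ((3-methoxyphenyl)amino in place of piperidin-1-yl on a double-bonded ring carbon), at the same place.

Compound 4 is expected to land near 5000 nM, somewhere between 1500 nM and 20000 nM. That estimate corresponds to an expected step of an at least 1.6-fold lower number from compound 3 to compound 4 (0.20 log units; that floor lies within the scatter), and rests on the measured step of an at least 2.0-fold lower number from compound 1 to compound 2 (0.31 log units; beyond the scatter) together with the limit seen for compound 3.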

Compound 4, half-maximal inhibitory concentration: > 4000 nM
Compound 4 gave a limit, no number; the forecaster's own chance of this, stated with the estimate: 45%; the middle value does not contradict the limit.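

Among these compounds, compound 3 and compound 4 both gave limits, not numbers, so the size of the change between them cannot be read and no new step follows. Going by these compounds, what stays open is whether (3-methoxyphenyl)amino in place of piperidin-1-yl lowers the number on the core of compound 3, as it does on the core of compound 1.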